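A few compounds are considered here, and "the series" means these few. Any claim that something is new, unique, unknown or untested is made for them only; others in the source may bear on it.

The measured compounds:
Compound 1, `CCC(=O)Nc1cccc(S(=O)(=O)Oc2ccccc2C(C)C)c1`, gives 12000 nM in a functional assay on HT-1080 cells (Homo sapiens) for antiproliferative activity, read by sulforhodamine B assay, with a stated time of 48 h; on this read-out higher numbers stand for weaker inhibition and lower numbers for stronger inhibition.
Compound 2, `CCCCCC(=O)Nc1ccc(S(=O)(=O)Oc2ccccc2C(C)C)cc1`, gives 6300 nM in this assay.
Compound 3, `CCCCCC(=O)Nc1ccc(S(=O)(=O)Oc2ccccc2I)cc1`, gives 9600 nM in this assay.

Compound 2 sits at the low end of these three numbers, yet neither gap to the others reaches beyond the scatter. For the measured compounds named here, the one recorded single-point step, a 1.5-fold higher number from compound 2 to compound 3 (0.18 log units; within the scatter), lies within the scatter, and compound 1 differs from compound 2 in more than one place, so only its value can be compared. Compound 4, `CCCCCNC(=O)Nc1ccc(S(=O)(=O)Oc2ccccc2C(C)C)cc1`, has not been measured. Its change from compound 2 is pentylamino in place of pentyl on a carbonyl carbon; cut one bond further out, the change reads pentylcarbonyl to pentylcarbamoyl. Going by the values given here, no measured step touches this part of the molecule: the step on record alters a group on an aromatic carbon elsewhere. Without a direct precedent, the expectation in this assay is no step beyond the scatter, so no change at the digits printed from compound 2 to compound 4 (within the scatter) is expected. Compound 4 is therefore estimated at 6300 nM, with a range from 2500 nM to 16000 nM.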

Compound 4, half-maximal inhibitory concentration: 4700 nM
Estimate against measurement, compound 4: 1.3-fold (0.13 log units) above; the range from low to high includes it.
By their numbers in this assay, from the lowest: compounds 4, 2, 3 and 1 (each within the scatter of the next, the first and the last beyond it).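

In this assay pentylamino in place of pentyl on the carbonyl carbon gives a 1.3-fold lower number from compound 2 to compound 4 (0.13 log units; within the scatter) and so leaves the number within the scatter. For the compounds shown here, this is the first look at this part of the molecule, since the earlier step altered a group on an aromatic carbon elsewhere. Here pentylcarbonyl and pentylcarbamoyl cannot be told apart, even though pentylamino carries a hydrogen-bond donor that pentyl lacks, and no measurement at hand accounts for this result.

From the compounds shown here alone, whether a shorter chain such as propylamino, or a chain ending in an amine or a carboxylic acid, would keep the number in this range on the same carbonyl carbon remains open. Also open, going by these compounds, is whether pentylamino would give a similar result alongside iodo in place of isopropyl on the aromatic carbon.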